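This account rests on a few compounds, and the source may have more. Where it says the series, first, only, none or still open, it means among the compounds named here.

Compound 1, `CCSC[C@@](O)([C@@H](Nc1cccc2nc(C)ccc12)c1ccc(OC)cc1)C(F)(F)F`, is the stronger of the two compounds measured here: in a functional assay on THP-1 cells (Homo sapiens) (on this read-out higher numbers stand for larger maximal responses and lower numbers for smaller maximal responses), compound 1 gives 86%, the highest of the two numbers. Compound 2, `CCSC[C@@](O)([C@@H](Nc1cccc2nc(C)ccc12)c1cccc(F)c1OC)C(F)(F)F`, gives 69% in this assay, and the change that separates them, 3-fluoro-2-methoxyphenyl in place of 4-methoxyphenyl, produced a number 17 percentage points lower from compound 1 to compound 2 (beyond the scatter).

Compound 3, `CCSC[C@@](O)([C@@H](Nc1cccc2nc(C)ccc12)c1ccc(OC)c(F)c1)C(F)(F)F`, differs from compound 1 by fluoro in place of hydrogen on an aromatic carbon. Among the compounds with values here, the only measured step, from compound 1 to compound 2, also brings in a fluorine but at the same time moves the methoxy group, so it bears on this change only loosely; its modest drop suggests that adding fluorine to this ring does not raise the maximal response. A small loss, or none beyond the scatter, is therefore expected in this assay, with the step from compound 1 to compound 3 estimated as a number 6 percentage points lower from compound 1 to compound 3 (within the scatter). Compound 3 is thus expected to give 80%, within the range 65% to 92%.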

Compound 3, largest response reached (Emax), in percent of the reference or control that the assay uses: 82%
Compound 3: middle estimate off by 2 percentage points, on the low side; the measured number falls inside the stated range.
By their numbers in this assay, from the lowest: compound 2; then compounds 3 and 1 (each within the scatter of the next).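

On the 4-methoxyphenyl ring, fluoro ortho to the methoxy group gives a number 4 percentage points lower from compound 1 to compound 3 (within the scatter) in this assay, so at this position the added fluorine leaves a change that cannot be told from the scatter. With fluorine present in both compounds, the ring change shows a number 13 percentage points higher from compound 2 to compound 3 (beyond the scatter) and this separates the two parts of the earlier step: the 3-fluoro-4-methoxyphenyl pattern keeps the larger maximal response, whereas the 3-fluoro-2-methoxyphenyl pattern gives a smaller one. Nothing measured here explains why the two ring patterns differ.

On these data alone, whether a chloro group or a nitrile at this same position would behave like fluoro remains open. Also open, as far as these compounds go, is how much of the lower response of compound 2 would persist with a plain 2-methoxyphenyl ring carrying no fluoro group.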